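Bromo to chloro on compound 3

The source may report more compounds than this note shows. Statements on the series, on what has been measured and on what is new or still open speak of the compounds shown alone.

In a functional assay on DU-145 cells (Homo sapiens) for inhibition, read by trypan blue exclusion, with a stated time of 96 h (on this read-out higher numbers stand for weaker inhibition of growth and lower numbers for stronger inhibition of growth), compound 2 `O=C(/C(=C\c1ccc(Br)cc1)Sc1ccccc1Br)c1ccc(Br)cc1` gives 1000 nM. Compound 3 `O=C(/C(=C\c1ccc(O)cc1O)Sc1ccccc1Br)c1ccc(Br)cc1` gives 50000 nM and compound 1 `O=C(/C(=C\c1ccc(O)cc1O)SCc1ccc(Cl)cc1)c1ccc(Cl)cc1` gives 50000 nM. These two are level at the digits shown and together hold the highest of the three numbers.

Next in line is compound 4 `O=C(/C(=C\c1ccc(O)cc1O)Sc1ccccc1Br)c1ccc(Cl)cc1`, not yet measured. Its change from compound 3 is chloro in place of bromo on an aromatic carbon, para to a large group, so that 4-bromophenyl becomes 4-chlorophenyl.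

Among the compounds with values here, the one measured step in a single place is a 50-fold higher number from compound 2 to compound 3 (1.70 log units; beyond the scatter). That large step brings in 2,4-dihydroxyphenyl in place of 4-bromophenyl, a different change, so it does not size this swap. Compound 4 keeps the 2,4-dihydroxyphenyl group of compound 3. The closest guide is compound 1 at 50000 nM, which also pairs 2,4-dihydroxyphenyl with (4-chlorophenyl)carbonyl, although it differs from compound 4 elsewhere.

In this assay, the expected no change at the digits printed from compound 3 to compound 4 (within the scatter) is no shift beyond the scatter. For compound 4 the estimated value is 50000 nM, with an expected range of 22000 nM to 100000 nM.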

Compound 4, concentration for 50% growth inhibition: 50000 nM
For compound 4 middle estimate and measured number coincide at the digits printed, within the range that was stated.
By their numbers in this assay, from the lowest: compound 2; then compounds 1, 3 and 4 (each within the scatter of the next).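

In this assay, within the data shown here, the first single-place reading at this aromatic carbon is no change at the digits printed from compound 3 to compound 4 (within the scatter), so with 2,4-dihydroxyphenyl on the other side of the shared core, 4-bromophenyl and 4-chlorophenyl cannot be told apart. Among these compounds, the sulfur substituent can now also be read in one place, with 2-bromophenyl in place of 4-chlorobenzyl giving no change at the digits printed from compound 1 to compound 4 (within the scatter), so that change also stays within the scatter, while a 50-fold higher number from compound 2 to compound 3 (1.70 log units; beyond the scatter) remains the only large step in the set. No supporting data bear on the absence of a shift at either place.

From the compounds shown here alone, it remains open whether the same bromo-to-chloro change would also stay within the scatter in the setting of compound 2, which carries 4-bromophenyl in place of 2,4-dihydroxyphenyl and has the lower number of the two. Going by these compounds, it is also open how a group of another kind on this aromatic carbon, such as an amine or a carboxylic acid, would read against the halogens.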